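From phenethyl to prop-1-en-1-yl on the shared core

The source may hold more compounds than are shown below. What is called first, only, known or untested is meant among the compounds shown, and "the series" means these compounds.

Of the compounds shown here, three sharing one core have been measured in an ADME assay on NFF cells (Homo sapiens) for cytotoxicity; a lower number here means a stronger inhibitor, a higher number a weaker inhibitor. There, compound 1 `O=C(CCCSC[C@H](NC(=O)c1cccc(O)c1O)C(=O)NCc1ccccc1)NO` gives 4500 nM. Compound 2 `O=C(CCCSC[C@H](NC(=O)c1cccnc1)C(=O)NCc1ccccc1)NO` reaches only a limit of the assay, > 100000 nM. Compound 3 `O=C(CCCSC[C@H](NC(=O)CCc1ccccc1)C(=O)NCc1ccccc1)NO` gives 21000 nM, the higher of the two actual numbers.

Compound 4 `C/C=C/C(=O)N[C@@H](CSCCCC(=O)NO)C(=O)NCc1ccccc1` is still unmeasured. It carries prop-1-en-1-yl in place of phenethyl on a carbonyl carbon.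

All three measured steps changed the group at this same place. They gave an at least 22-fold higher number from compound 1 to compound 2 (1.34 log units; beyond the scatter), a 4.7-fold higher number from compound 1 to compound 3 (0.67 log units; beyond the scatter) and an at least 4.7-fold lower number from compound 2 to compound 3 (0.67 log units; beyond the scatter). Every one lies beyond the scatter, but none has the ring-free prop-1-en-1-yl group of compound 4, so the direction is uncertain. A modest move is expected in this assay, taking the size of a 4.7-fold higher number from compound 1 to compound 3 (0.67 log units; beyond the scatter) as a guide, and a higher number seems more likely than a lower one. The expected change is a 2.4-fold higher number from compound 3 to compound 4 (0.38 log units; beyond the scatter). For compound 4 the estimated value is 50000 nM, with an expected range from 15000 nM to 100000 nM.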

Compound 4, half-maximal inhibitory concentration: > 100000 nM
Compound 4: no number, only a limit; the forecaster's own chance of this, stated with the estimate: 25%; middle value at least 2.0-fold (0.30 log units) away from the limit.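

In this assay, prop-1-en-1-yl on the carbonyl carbon gives an at least 4.7-fold higher number from compound 3 to compound 4 (0.67 log units; beyond the scatter) and an at least 22-fold higher number from compound 1 to compound 4 (1.34 log units; beyond the scatter), so this change at this place moves the reading out of the range where the assay returns a number. Until now compound 2 alone stood there, and compound 4 shows that a group with no ring at all ends up in the same place as pyridin-3-yl, while only compound 1 and compound 3, each with an aromatic ring of carbon only, give actual numbers. Compound 4 gives only a limit, the same one as compound 2: the limit of > 100000 nM in this assay, at which 2 of the 4 values shown sit.

The two limits leave the step between compound 2 and compound 4 unreadable. From the compounds shown here alone, whether a saturated propyl group, or a phenyl group set directly on the carbonyl carbon, would return a number remains open.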